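Methyl for Fluoro on the Fused Ring of Compound 4

This account rests on a few compounds, and the source may have more. Where it says the series, first, only, none or still open, it means among the compounds named here.

Three compounds share an acetamide-bearing aryl attached to a fused two-ring core. Compound 1 `Cc1ccc2oc(-c3ccc(NC(=O)CCl)cc3)nc2c1` carries a methyl on that core and a chloroacetamide; compound 2 `O=C(CCl)Nc1ccc(-c2nc3cc(F)ccc3o2)cc1` carries a fluoro in the same place with the same chloroacetamide; compound 3 `Cc1cc(-c2nc3cc(F)ccc3o2)ccc1NC(=O)CN1CCN(CCCN(C)C)CC1` keeps the fluoro but bears a piperazine-linked acetamide and a methyl on the aryl ring.

In a functional assay on HT-29 cells (Homo sapiens) for cytotoxicity, read by MTT assay, with a stated time of 24 h (on this read-out higher numbers stand for weaker inhibition and lower numbers for stronger inhibition), compound 1 gives 15200 nM. Compound 2 gives 6930 nM, and compound 3 gives 6700 nM. For the measured compounds named here, the one measured step of a single change is a 2.2-fold higher number from compound 2 to compound 1 (0.34 log units; beyond the scatter), the change being (methyl in place of fluoro on an aromatic carbon). The difference between the cores of compound 2 and compound 3 is not broken down here; their two values lie close together.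

Compound 4 `Cc1ccc2oc(-c3ccc(NC(=O)CN4CCN(CCCN(C)C)CC4)c(C)c3)nc2c1` is not yet measured. It differs from compound 3 by methyl in place of fluoro on an aromatic carbon, the same change that turns compound 2 into compound 1, at the same place. The expectation for compound 4 therefore rests on compound 2 and compound 1, whose step a 2.2-fold higher number from compound 2 to compound 1 (0.34 log units; beyond the scatter) went upward, and on the starting point of compound 3 at 6700 nM. The step from compound 3 to compound 4 is expected to be about a 2.0-fold higher number from compound 3 to compound 4 (0.30 log units; within the scatter). Compound 4 is thus estimated at 13500 nM, with a range expected from 6000 nM to 30000 nM.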

Compound 4, half-maximal inhibitory concentration: 12700 nM
For compound 4 the middle estimate is 1.1-fold (0.03 log units) above the measured one, and the stated range covers the measured number.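

In this assay, the exchange of the 5-fluoro-1,3-benzoxazol-2-yl group for the 5-methyl-1,3-benzoxazol-2-yl group on the core carrying the piperazine-linked acetamide gives a 1.9-fold higher number from compound 3 to compound 4 (0.28 log units; within the scatter). Set beside the step seen with the chloroacetamide pair, this shows that the change carries over between these two cores with a size that cannot be told apart: the same change on two cores in this assay, a 2.2-fold higher number (0.34 log units; beyond the scatter) from compound 2 to compound 1 and a 1.9-fold higher number (0.28 log units; within the scatter) from compound 3 to compound 4, 1.2-fold (0.06 log units) apart, within the scatter of two such steps This agreement does not show that the change has a real effect on the second core, since the new step taken alone lies within the scatter, and two pairs in a single cell line cannot establish a rule for the series or say why the two steps agree.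

The compounds shown leave open whether the agreement would persist with other groups on that aromatic carbon, such as chloro, methoxy or a plain hydrogen. They also leave open whether it would hold on cores bearing a morpholine or a longer chain in place of the piperazine-linked side chain.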